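Notes on the aryl change from compound 3 to compound 4

The source may hold more compounds than are shown below. What is called first, only, known or untested is meant among the compounds shown, and "the series" means these compounds.

In a functional assay on MDA-MB-231 cells (Homo sapiens) for cytotoxicity, read by MTT assay, with a stated time of 48 h (a lower number here means a stronger inhibitor, a higher number a weaker inhibitor), compound 1 `CC(=O)Nc1ccc(NC(=O)NCCCCC(c2ccc(F)cc2)c2ccc(F)cc2)cc1` reaches only a limit, > 20000 nM. Compound 2 `O=C(NCCCCC(c1ccc(F)cc1)c1ccc(F)cc1)Nc1cccc(Cl)c1` gives 5070 nM and compound 3 `O=C(NCCCCC(c1ccc(F)cc1)c1ccc(F)cc1)Nc1cccc([N+](=O)[O-])c1` gives 3790 nM, so compound 3 stands level with compound 2 within the scatter. Compound 4 `O=C(NCCCCC(c1ccc(F)cc1)c1ccc(F)cc1)Nc1ccc(Cl)c(C(F)(F)F)c1` carries 4-chloro-3-(trifluoromethyl)phenyl in place of 3-nitrophenyl on an amide-type nitrogen. The nearest measured step is a 1.3-fold lower number from compound 2 to compound 3 (0.13 log units; within the scatter). The larger steps, an at least 3.9-fold lower number from compound 1 to compound 2 (0.59 log units; beyond the scatter) and an at least 5.2-fold lower number from compound 1 to compound 3 (0.72 log units; beyond the scatter), both start from the 4-acetamidophenyl group, which plays no part in this change. No step beyond the scatter is therefore expected in this assay, and the estimated step is a 1.1-fold lower number from compound 3 to compound 4 (0.03 log units; within the scatter). For compound 4 the estimate is 3500 nM, with an expected range of 1400 nM to 8000 nM.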

Compound 4, half-maximal inhibitory concentration: 3150 nM
The estimate for compound 4 lay 1.1-fold (0.05 log units) above the measured number; measured number inside the range.
By their numbers in this assay, from the lowest: compounds 4, 3 and 2 (each within the scatter of the next). At a limit, above all of these: compound 1.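

On the amide-type nitrogen, 4-chloro-3-(trifluoromethyl)phenyl reads level with 3-nitrophenyl in this assay (a 1.2-fold lower number from compound 3 to compound 4 (0.08 log units; within the scatter)) and with 3-chlorophenyl (a 1.6-fold lower number from compound 2 to compound 4 (0.21 log units; within the scatter)), so adding a second ring substituent does not separate these aryl groups. The 4-acetamidophenyl group stays apart (an at least 6.3-fold lower number from compound 1 to compound 4 (0.80 log units; beyond the scatter)), and that step starts from a limit, not a number: the limit of > 20000 nM in this assay, at which 1 of the 4 values shown sits.

From the compounds shown here alone, whether an amine or a carboxylic acid on the aryl ring would move the number in this assay stays open. So does the effect of a longer chain in the shared core.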